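The source may report more compounds than this note shows. Statements on the series, on what has been measured and on what is new or still open speak of the compounds shown alone.

Of the compounds shown here, two of one family have been tested in a functional assay on HeLa cells (Homo sapiens) for antiproliferative activity, with a stated time of 24 h; a lower number here means a stronger inhibitor, a higher number a weaker inhibitor. Compound 1 `NC(=O)c1c(NC(=O)c2ccccc2F)sc2c1CCN(Cc1ccc(Cl)cc1Cl)C2` gives 27500 nM in this assay, a weak result. Compound 2 `NC(=O)c1c(NC(=O)c2ccccc2I)sc2c1CCN(C(=S)Nc1ccccc1Cl)C2` reaches only the limit of this assay, > 50000 nM, so no number is known for it. This is the situation described by the limit of > 50000 nM in this assay, at which 1 of the 2 values shown sits: one of the two values sits at that limit rather than being a number. The next compound, compound 3 `NC(=O)c1c(NC(=O)c2cccc([N+](=O)[O-])c2)sc2c1CCN(C(=S)Nc1ccccc1Cl)C2`, differs from compound 2 in one place: 3-nitrophenyl in place of 2-iodophenyl on a carbonyl carbon. Among the compounds with values here, both measured compounds are weak, and no measured pair shows how this kind of exchange moves the read-out in this assay. The step of an at least 1.1-fold lower number from compound 2 to compound 3 (0.04 log units; that floor lies within the scatter) that is expected here is therefore small, with no clear direction beyond the scatter. Compound 3 is expected to give about 45000 nM in this assay, most likely between 15000 nM and 100000 nM, and it may well come back as a limit again.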

Compound 3, half-maximal inhibitory concentration: 40300 nM
Estimate against measurement, compound 3: 1.1-fold (0.05 log units) above; the measured number falls inside the stated range.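

Compound 2 stands at a limit of the assay and not at a number: the limit of > 50000 nM in this assay, at which 1 of the 3 values shown sits. In this assay compound 3 gives 40300 nM, so this position on the carbonyl carbon now carries a real number, and the exchange of 2-iodophenyl for 3-nitrophenyl reads as an at least 1.2-fold lower number from compound 2 to compound 3 (0.09 log units; that floor lies within the scatter). That floor lies within the scatter, so the result does not establish that this change improves activity, although the true step could be larger than the floor.

Going by these compounds, it remains open whether any group at this position can bring the number well below these weak values. A phenyl ring carrying an amine or a carboxylic acid, or a small alkyl chain in place of the ring, would show how much this position can move the read-out.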